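A few compounds are considered here, and "the series" means these few. Any claim that something is new, unique, unknown or untested is made for them only; others in the source may bear on it.

Two compounds here have been run through an ADME assay on the whole organism (strain Sprague-Dawley) for pharmacokinetics, with Rattus norvegicus as the target, read by LC-MS, at a dose of 50 mg/kg by the oral route (a higher number here means that a larger share of the oral dose reaches the circulation, a lower number that a smaller share of the oral dose reaches the circulation), and they sit far apart. Compound 1, `CCC(CC)O[C@@H]1C=C(C(=O)O)C[C@H](NC(C)=N)[C@H]1NC(C)=O`, carries a free acid on the shared core and in this assay gives 3.9%, the lowest of the two numbers. Compound 2, `CCOC(=O)C1=C[C@@H](OC(CC)CC)[C@H](NC(C)=O)[C@@H](N/C(C)=N/O)C1`, carries an ethyl ester in that place and a different nitrogen-bearing group on the core, and in this assay compound 2 gives 31.4%, a gap to compound 1 well beyond the scatter. Compound 2 differs from compound 1 in two places at once. Among the compounds with values here, no single step between them can be drawn.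

Compound 3, `CCOC(=O)C1=C[C@@H](OC(CC)CC)[C@H](NC(C)=O)[C@@H](NC(C)=N)C1`, has not yet been measured. It keeps the nitrogen-bearing groups of compound 1 and changes only one thing: ethyl in place of hydrogen on an oxygen next to a carbonyl group. That is the ester of compound 2 placed on the core of compound 1. Within the data shown here, the ester is the one feature compound 2 shares with compound 3, and compound 2 gives 31.4%, so a rise is expected, with the step of a number 26.1 percentage points higher from compound 1 to compound 3 (beyond the scatter) estimated as large. For compound 3 in this assay the expected value is 30%, within a range from 10% to 55%.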

Compound 3, oral bioavailability in the Rattus norvegicus assay: 0.8%
Beside the measured number, compound 3's estimate is 29.2 percentage points above it; measured number below the stated range.
By their numbers in the Rattus norvegicus assay, from the lowest: compounds 3 and 1 (each within the scatter of the next); then compound 2.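

In the Rattus norvegicus assay, ethyl in place of hydrogen on an oxygen next to a carbonyl group, the change from carboxy to ethoxycarbonyl, gives a number 3.1 percentage points lower from compound 1 to compound 3 (within the scatter), so on this core the ester alone does not bring the oral number seen for the ester with the other nitrogen group. With the ester kept, the change on the amine nitrogen, a group of 3 heavy atoms in place of a group of 4 heavy atoms, gives a number 30.6 percentage points lower from compound 2 to compound 3 (beyond the scatter), which places the large difference in this set at that nitrogen and not at the ester. In a physicochemical assay for solubility, read by HPLC, in phosphate buffer, with a stated time of 20 min, at pH 2.0 (a lower number here means a less soluble compound, a higher number a more soluble compound), compound 1 gives > 50000000 nM, and compound 1's value is a limit of the assay, as is the next one; in the same assay, the physicochemical assay, compound 3 gives > 50000000 nM, also a limit.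

The solubility step for the ester change cannot be read, and how far either compound lies past the limit stays open: the limit of > 50000000 nM in the physicochemical assay, at which 2 of the 2 values shown sit.

Also open, from the compounds shown here alone, are how a methyl or a longer chain in place of the ethyl on that oxygen would read, and how a plain amine on the amine nitrogen would compare.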